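Swapping the Aryl Group: From Aminopyridine to Thiazole

The source may report more compounds than this note shows. Statements on the series, on what has been measured and on what is new or still open speak of the compounds shown alone.

Measured compounds:
compound 1 `CCC(C)(C)Cc1c[nH]c(CCc2ccc(-c3cccc(C#N)n3)cc2)n1` – 115 nM
compound 2 `CCC(C)(C)Cc1c[nH]c(CCc2ccc(-c3ccccc3C(=O)O)cc2)n1` – 94 nM
compound 3 `CCC(C)(C)Cc1c[nH]c(CCc2ccc(-c3cccc(N)n3)cc2)n1` – 119 nM

All three compounds share one core and differ only in the aromatic group attached on an aromatic carbon. In a functional assay on HEK293 cells for agonist activity at Bombesin receptor subtype-3 (Mus musculus), read by luminescence and calcium flux, with a stated time of 10 min (on this read-out higher numbers stand for an effect only at larger amounts of compound and lower numbers for an effect already at smaller amounts), compound 3 gives 119 nM. The three numbers sit close together: the change a 1.0-fold higher number from compound 1 to compound 3 (0.01 log units; within the scatter) and the change a 1.3-fold higher number from compound 2 to compound 3 (0.10 log units; within the scatter) both stay within the scatter, as does a 1.2-fold lower number from compound 1 to compound 2 (0.09 log units; within the scatter). So compound 3 stands among the others without a distinct difference.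

Compound 4 `CCC(C)(C)Cc1c[nH]c(CCc2ccc(-c3cnsc3)cc2)n1` has not yet been measured. Relative to compound 3 the change is 1,2-thiazol-4-yl in place of 6-aminopyridin-2-yl on an aromatic carbon. The three measured steps all exchange the aromatic group at this position, and none of them moved the number beyond the scatter, whether a nitrile, an amino group, a carboxylic acid or a different ring was present. Among the measured compounds shown here, those steps are the only evidence that bears on this change; the thiazole itself has no measured precedent here. The expectation for compound 4 is therefore a step of about a 1.1-fold higher number from compound 3 to compound 4 (0.04 log units; within the scatter), that is, no shift beyond the scatter. The estimated value for compound 4 in this assay is 130 nM, with a range from 50 nM to 350 nM.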

Compound 4, half-maximal effective concentration: 119 nM
Beside the measured number, compound 4's estimate is 1.1-fold (0.04 log units) above it; low and high end bracket the measured number.
By their numbers in this assay, from the lowest: compounds 2, 1, 3 and 4 (each within the scatter of the next).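

In this assay, the exchange of 6-aminopyridin-2-yl for 1,2-thiazol-4-yl gives no change at the digits printed from compound 3 to compound 4 (within the scatter), even though the entering group has a five-membered aromatic ring with 5 heavy atoms and 0 hydrogen-bond donors, while the leaving group has a six-membered aromatic ring with 7 heavy atoms and 1 hydrogen-bond donor. Among the compounds shown here, the other comparisons agree, with a 1.3-fold higher number from compound 2 to compound 4 (0.10 log units; within the scatter) and a 1.0-fold higher number from compound 1 to compound 4 (0.01 log units; within the scatter), so this position, which had so far carried only six-membered aromatic rings, now also accepts a smaller five-membered aromatic ring containing sulfur without a shift beyond the scatter. Nothing in the available data explains why these exchanges leave the number within the scatter.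

The compounds shown leave open whether the number would also stay put with a non-aromatic ring such as piperidine, or with a small group such as methyl or a plain hydrogen in place of the ring. They also leave open whether an amide or a longer carbon chain on the thiazole would finally move the number beyond the scatter.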